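A few compounds are considered here, and "the series" means these few. Any claim that something is new, unique, unknown or untested is made for them only; others in the source may bear on it.

Working notes on the series.

Compound 1 `Nc1cc(N)c2nc(-c3ccccc3)c(NCc3ccc(Cl)c(Cl)c3)nc2c1`, compound 2 `COc1ccc(CNc2nc3cc(N)cc(N)c3nc2-c2ccccc2)cc1OC` and compound 3 `Nc1cc(N)c2nc(-c3ccccc3)c(NCc3ccc(F)cc3)nc2c1` share one core and differ only in the benzyl group on the ring-bound nitrogen. In a functional assay on K562 cells (Homo sapiens) for inhibition, read by sulforhodamine B assay, with a stated time of 48 h (a higher number here means that more compound is tolerated, a lower number that less compound is tolerated), compound 1 gives < 100000 nM, which is a limit of the assay and not a number. In this assay compound 2 likewise gives only the limit < 100000 nM. Compound 3 too is reported only as the limit < 100000 nM. Every value shown sits at the limit of < 100000 nM in this assay, at which 3 of the 3 values shown sit. The steps a step that the two limits leave unreadable from compound 1 to compound 2, a step that the two limits leave unreadable from compound 1 to compound 3 and a step that the two limits leave unreadable from compound 2 to compound 3 are therefore unreadable in size, and compound 3 stands at the same limit as the other two, with no number to place it.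

Compound 4 `COc1ccc(CNc2nc3cc(N)cc(N)c3nc2-c2ccccc2)cc1` is the next member: methoxy in place of fluoro on an aromatic carbon. Going by the values given here, none of the measured steps gives a readable size, and all three concern changes on this same benzyl ring, so no direction beyond the scatter can be drawn from them. The expected step is a step that the limit leaves unreadable from compound 3 to compound 4, essentially none. Compound 4 is accordingly estimated at 30000 nM, with a range from 5000 nM to 100000 nM, and a limit rather than a number is the more likely report.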

Compound 4, concentration lethal to 50% of the cells: < 100000 nM
Compound 4 was reported as a limit (the forecaster's own chance of this, stated with the estimate: 70%); the middle value is on the limit's open side.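

In this assay compound 4, like compound 1, compound 2 and compound 3, is reported only as a limit, so no new step can be read: the limit of < 100000 nM in this assay, at which 4 of the 4 values shown sit.

The compounds shown leave open whether any benzyl group on the shared core gives a number in this assay rather than a limit, and how the four compounds compare.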